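Swapping the ring substituent on the piperazine of compound 1

The source may hold more compounds than are shown below. What is called first, only, known or untested is meant among the compounds shown, and "the series" means these compounds.

Measured compounds:
- compound 1, `Cc1nc(N2CCN(C3CCOCC3)CC2)nc2ccc(NC(=O)COc3ccc(Cl)cc3)cc12`, 45 nM
- compound 2, `Cc1nc(N2CCN(C3CCOCC3)CC2)nc2ccc(NC(=O)COc3ccc(OC(F)(F)F)cc3)cc12`, 7 nM
- compound 3, `Cc1nc(N2CCN(C(=O)C3CCC3)CC2)nc2ccc(NC(=O)COc3ccc(OC(F)(F)F)cc3)cc12`, 84 nM

These three compounds share a core and were compared in an assay on CHO-K1 cells for displacement of a labelled ligand from melanin-concentrating hormone receptor 1 (Homo sapiens), with a stated time of 2 h; on this read-out lower numbers stand for stronger inhibition and higher numbers for weaker inhibition. Compound 1 gives 45 nM, the second highest of the three numbers; its nearest neighbour is compound 3, and the gap between the two lies within the scatter, while compound 2 stands well apart, with a 6.4-fold lower number from compound 1 to compound 2 (0.81 log units; beyond the scatter). Going by the values given here, at the amine nitrogen in a ring, the single measured step is a 12-fold higher number from compound 2 to compound 3 (1.08 log units; beyond the scatter).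

Compound 4, `Cc1nc(N2CCN(CC(C)(C)C)CC2)nc2ccc(NC(=O)COc3ccc(Cl)cc3)cc12`, differs from compound 1 in one place: neopentyl in place of oxan-4-yl on an amine nitrogen in a ring. Among the compounds with values here, no measured step involves neopentyl. Within the data shown here, the only step at this position, from compound 2 to compound 3, introduced cyclobutylcarbonyl rather than an alkyl group, so it bears on compound 4 only loosely. A step of modest size toward a higher number is expected, a 1.6-fold higher number from compound 1 to compound 4 (0.19 log units; within the scatter), and compound 4 is estimated at 70 nM, within a range of 20 nM to 250 nM.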

Compound 4, half-maximal inhibitory concentration: 782 nM
Estimate against measurement, compound 4: 11-fold (1.05 log units) below; measured number outside the range, above it.
By their numbers in this assay, from the lowest: compound 2; then compounds 1 and 3 (each within the scatter of the next); then compound 4.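

In this assay, going by these compounds alone, neopentyl in place of oxan-4-yl on an amine nitrogen in a ring gives a 17-fold higher number from compound 1 to compound 4 (1.24 log units; beyond the scatter), the first measured step at this position to an alkyl group with no ring and no hydrogen-bond acceptor. Alongside a 12-fold higher number from compound 2 to compound 3 (1.08 log units; beyond the scatter), it shows that both replacements of oxan-4-yl seen here, one on the chloro compound and one on the trifluoromethoxy compound, raise the number beyond the scatter. No measurement shown here accounts for the size of the new step.

The compounds shown leave open whether the ring or its oxygen matters more, as neopentyl lacks both at once. A cyclohexyl group would keep the ring without the oxygen, while an open chain carrying an ether oxygen would keep the oxygen without the ring.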